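From 2-hydroxyethyl to 3-hydroxypropyl on a sulfonyl chain

This account rests on a few compounds, and the source may have more. Where it says the series, first, only, none or still open, it means among the compounds named here.

Measured so far in a physicochemical assay for acid dissociation
- compound 1 `NS(=O)(=O)c1ccc(S(=O)(=O)CCCO)c([N+](=O)[O-])c1` gives 8
- compound 2 `COC(=O)c1cc(S(N)(=O)=O)ccc1S(=O)(=O)CCCO` gives 8.9
- compound 3 `Nc1cc(S(N)(=O)=O)ccc1S(=O)(=O)CCO` gives 9.5

Compound 3 has the highest number of the three, and its gaps to compound 2 and compound 1 both lie beyond the scatter. Compound 4 `Nc1cc(S(N)(=O)=O)ccc1S(=O)(=O)CCCO` has not yet been measured. It differs from compound 3 by hydroxymethyl in place of hydroxy on a saturated chain carbon, two bonds along the chain from a sulfonyl sulfur which means hydroxymethyl in place of hydroxy on a saturated chain carbon, two bonds along the chain from a sulfonyl sulfur. Put another way, 2-hydroxyethyl becomes 3-hydroxypropyl.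

Going by the values given here, no measured pair shows this change alone. Among the compounds with values here, the one measured step is a number 0.90 log units higher from compound 1 to compound 2 (beyond the scatter) and it concerns methoxycarbonyl in place of nitro on an aromatic carbon, a different place altogether. It therefore gives no size to carry over, and compound 3 at 9.5 remains the starting point for the estimate. The expected change is small, with a number 0.10 log units higher from compound 3 to compound 4 (within the scatter) as the estimate and no step beyond the scatter expected. Compound 4 is expected at 9.6 with an estimated range from 9.2 to 10 in this assay when it is measured.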

Compound 4, acid dissociation constant: 9.15
Compound 4: the middle estimate sits 0.45 log units above what was measured; the whole stated range lies above it.
By their numbers in this assay, from the lowest: compound 1; then compounds 2 and 4 (each within the scatter of the next); then compound 3.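

In this assay, going by these compounds alone, the sulfonyl chain proves not to be a silent place: 2-hydroxyethyl to 3-hydroxypropyl gives a number 0.35 log units lower from compound 3 to compound 4 (beyond the scatter) and is the first change at this chain to be read at all. With 3-hydroxypropyl held constant, amino in place of nitro gives a number 1.15 log units higher from compound 1 to compound 4 (beyond the scatter) while amino in place of methoxycarbonyl gives a number 0.25 log units higher from compound 2 to compound 4 (within the scatter) and so cannot be told apart from repeat-measurement noise. Nothing available explains why the longer chain gives the lower number.

Within the data shown here, this chain change is seen in only one pair, with amino on the aromatic carbon, so it remains open whether it holds with nitro or methoxycarbonyl there. Also open, from the compounds shown here alone, is how a longer chain such as 4-hydroxybutyl, or an amine or carboxylic acid in place of the chain's hydroxy, would read.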